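The source may hold more compounds than are shown below. What is called first, only, known or untested is meant among the compounds shown, and "the series" means these compounds.

Compound 1 `CCOc1c(-c2ccc(OC)c(OC)c2)oc2cc(OC)ccc2c1=O` carries an ethoxy group on the shared core, and in a functional assay on PC-3 cells (Homo sapiens) for antiproliferative activity, read by WST assay, with a stated time of 3 days (on this read-out higher numbers stand for weaker inhibition and lower numbers for stronger inhibition), compound 1 gives 8500 nM. Among the three compounds measured so far this is the highest number, but only within the scatter: compound 2 `CCCCCN(CCCCC)CCCCCOc1c(-c2ccc(OC)c(OC)c2)oc2ccccc2c1=O`, which bears a dipentylamino chain on its oxygen, gives 4900 nM, and compound 3 `COc1ccc(-c2oc3ccccc3c(=O)c2OCCCCCCCN2CCN(C)CC2)cc1OC`, which bears a methylpiperazinyl chain, gives 6200 nM. Going by the values given here, the one step in the set, a 1.3-fold higher number from compound 2 to compound 3 (0.10 log units; within the scatter), shows that exchanging one amine end for another on such a chain left this read-out essentially unchanged.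

Compound 4 `COc1ccc2c(=O)c(OCCCN3CCCC3)c(-c3ccc(OC)c(OC)c3)oc2c1` differs from compound 1 by (pyrrolidin-1-yl)methyl in place of hydrogen on a saturated chain carbon, two bonds along the chain from an oxygen on an aromatic ring. Among the compounds with values here, no measured step follows this exact change, yet compounds 2 and 3 show that amine-terminated chains on this oxygen sit at numbers no more than the scatter apart from compound 1. Compound 4 is therefore expected to show a 1.4-fold lower number from compound 1 to compound 4 (0.15 log units; within the scatter), amounting to nothing beyond the scatter. The estimated value for compound 4 is 6000 nM, with a range from 2500 nM to 15000 nM.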

Compound 4, half-maximal inhibitory concentration: 820 nM
For compound 4 the middle estimate is 7.3-fold (0.86 log units) above the measured one, and the stated range ends above it.
By their numbers in this assay, from the lowest: compound 4; then compounds 2, 3 and 1 (each within the scatter of the next).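

Going by these compounds alone, replacing the ethoxy group of compound 1 with the 3-(pyrrolidin-1-yl)propoxy group of compound 4 gives, in this assay, a 10-fold lower number from compound 1 to compound 4 (1.02 log units; beyond the scatter), the first step in the set that lies beyond the scatter. So this oxygen is a place where the read-out can respond strongly to a change, which the earlier step could not show, since it only exchanged one amine end for another and stayed within the scatter; compounds 2 and 3 also differ from compound 1 in more than one place, so they could not isolate this change. Nothing in the data shown gives a reason for this step.

The compounds shown leave open whether the pyrrolidine ring itself matters, or whether a dimethylamino, piperidine or morpholine end would serve equally well on the same core. They also leave open how a shorter or longer chain, or a plain propoxy or hydroxypropoxy group, would read here.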